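A few compounds are considered here, and "the series" means these few. Any claim that something is new, unique, unknown or untested is made for them only; others in the source may bear on it.

Measured so far:
compound 1 `Cc1cccc(CCCN2CCc3nc(C)c([C@H](OC(C)(C)C)C(=O)O)c(-c4cc(F)c5c(c4C)CCCO5)c3C2)c1`, > 40000 nM
compound 2 `Cc1ccc(-c2c3c(nc(C)c2[C@H](OC(C)(C)C)C(=O)O)CCN(C(=O)CCc2ccccc2)C3)cc1`, > 40000 nM

Both measured entries reach only the ceiling of an ADME assay on MT2 cells (Homo sapiens) for cytotoxicity, read by XTT assay, with a stated time of 4 days; a higher number here means that more compound is tolerated, a lower number that less compound is tolerated. For compound 1 the value > 40000 nM is a limit of the assay and not a number. For compound 2 the value > 40000 nM is likewise a limit. Compound 1 therefore stands exactly where every value gathered so far stands, at the limit of > 40000 nM in this assay, at which 2 of the 2 values shown sit, and nothing in the data separates it from compound 2 in this assay. Among the measured compounds shown here, no two measured compounds differ in a single place, so no measured step is available to calibrate the change at hand.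

Compound 3 `Cc1nc2c(c(-c3cc(F)c4c(c3C)CCCO4)c1[C@H](OC(C)(C)C)C(=O)O)CN(CCCc1ccccc1F)CC2` is the next candidate. It differs from compound 1 by 2-fluorophenyl in place of 3-methylphenyl on a saturated chain carbon, three bonds along the chain from an amine nitrogen in a ring. With both measured compounds sitting at the limit, no shift beyond the usual scatter is expected in this assay, in either direction. The expected step is a step that the limit leaves unreadable from compound 1 to compound 3, that is, none worth noting. Compound 3 is accordingly expected to give 50000 nM, with a range from 20000 nM to 150000 nM, and most probably the assay will again report only a limit.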

Compound 3, half-maximal cytotoxic concentration: > 40000 nM
Compound 3 was reported as a limit; the forecaster's own chance of this, stated with the estimate: 75%; the middle value is on the limit's open side.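

Compound 1 and compound 3 both give only a limit in this assay, so no step between them can be read: the limit of > 40000 nM in this assay, at which 3 of the 3 values shown sit.

The compounds shown leave open where any of them would reach a half-maximal cytotoxic concentration in this assay, and whether 2-fluorophenyl in place of 3-methylphenyl shifts that concentration at all.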